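The compounds below may be only part of what the source reports. "The series", "measured", "known", "first", "only" and "open" are said of these compounds alone.

Measured in an ADME assay on microsomes from liver (Homo sapiens) for metabolic stability; a higher number here means faster removal of the compound, a lower number slower removal:
- Compound 1 `Cc1ccc(C(=O)Nc2cn3ncnc3c(CN3CCN(C(=O)CC(C(F)(F)F)C(F)(F)F)[C@@H](C)C3)c2C)cn1`: < 10 mL.min-1.g-1, a limit of the assay and not a number.
- Compound 2 `Cc1ccc(C(=O)Nc2cn3ncnc3c(O[C@@H]3CCN(C(=O)CC(C(F)(F)F)C(F)(F)F)[C@@H](C)C3)c2C)cn1`: 28 mL.min-1.g-1
- Compound 3 `Cc1ccc(C(=O)Nc2cn3ncnc3c(CN3CCN(C(=O)C(C)C)[C@@H](C)C3)c2C)cn1`: 240 mL.min-1.g-1

Compound 3 has the highest of the two true numbers in this assay, with compound 2 lower at 28 mL.min-1.g-1.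

Compound 4 `Cc1ccc(C(=O)Nc2cn3ncnc3c(CN3CCN(C(=O)CCC(F)(F)F)[C@@H](C)C3)c2C)cn1` keeps the rest of compound 3 but has 3,3,3-trifluoropropyl in place of isopropyl on a carbonyl carbon. Among the compounds with values here, the one measured step that bears on this change is at the same place, where isopropyl replaces 3,3,3-trifluoro-2-(trifluoromethyl)propyl: an at least 24-fold higher number from compound 1 to compound 3 (1.38 log units; beyond the scatter). There the fluorinated chain goes with the lower number. The chain in compound 4 is a different one, so only part of that step is expected to carry over, though still in the same direction and beyond the scatter.

The expected step is a 3.4-fold lower number from compound 3 to compound 4 (0.54 log units; beyond the scatter). For compound 4 the estimated value is 70 mL.min-1.g-1, with an expected range of 25 mL.min-1.g-1 to 170 mL.min-1.g-1.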

Compound 4, intrinsic clearance in microsomes: < 10 mL.min-1.g-1
Compound 4: a limit, no number; the forecaster's own chance of this, stated with the estimate: 10%; middle value at least 7.0-fold (0.84 log units) away from the limit.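

In this assay, 3,3,3-trifluoropropyl in place of isopropyl on the carbonyl carbon gives an at least 24-fold lower number from compound 3 to compound 4 (1.38 log units; beyond the scatter), so a large step at this position does not require the branched chain of compound 1 with its two trifluoromethyl groups. Compound 4 gives a limit of the assay and not a number, the same limit as compound 1: the limit of < 10 mL.min-1.g-1 in this assay, at which 2 of the 4 values shown sit. The step between compound 1 and compound 4 cannot be read, so the compounds put no size on the difference between one trifluoromethyl group and two at this place.

Whether the step follows the fluorine atoms or the chain itself stays open, as a plain propyl group on the same carbonyl carbon is not among these compounds. As far as these compounds go, how far compound 4 lies beyond its limit also stays open.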